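From ethoxycarbonyl to carbamoyl on a shared core

The source may hold more compounds than are shown below. What is called first, only, known or untested is meant among the compounds shown, and "the series" means these compounds.

compound 1 `CCNC(=O)c1noc(-c2cc(C(C)C)c(O)cc2O)c1-c1cc(COCC(=O)OC)no1` gives "not determined" (no result reported)
compound 2 `CCNC(=O)c1noc(-c2cc(C(C)C)c(O)cc2O)c1-c1cc(CN(CC)CC)no1` gives 78 nM
compound 3 `CCNC(=O)c1noc(-c2cc(C(C)C)c(O)cc2O)c1-c1cc(C(=O)OCC)no1` gives 9000 nM

In a functional assay on A2780 cells (Homo sapiens) for inhibition (on this read-out higher numbers stand for weaker inhibition and lower numbers for stronger inhibition), only two of these compounds carry a number. Compound 3 holds the higher one at 9000 nM and so shows the weaker inhibition of that pair, while compound 1 has no result to compare.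

Compound 4 `CCNC(=O)c1noc(-c2cc(C(C)C)c(O)cc2O)c1-c1cc(C(N)=O)no1` has yet to be measured. It departs from compound 3 through amino in place of ethoxy on a carbonyl carbon as the change, with amino in place of ethoxy on a carbonyl carbon, so that ethoxycarbonyl becomes carbamoyl.

Within the data shown here, only one measured step involves this group. It is a 120-fold higher number from compound 2 to compound 3 (2.06 log units; beyond the scatter) for ethoxycarbonyl in place of (diethylamino)methyl, a large step beyond the scatter. Among the measured compounds shown here, that is a different exchange, and no measured pair swaps ethoxy for amino, so it shows only that changes on this aromatic carbon can move the number far. With compound 3 at 9000 nM as the top of the measured numbers, a moderate step to a lower number in this assay is expected, smaller than that one and uncertain in size. The estimated change is a 9.0-fold lower number from compound 3 to compound 4 (0.95 log units; beyond the scatter) in the expected direction of stronger inhibition. For compound 4 the estimated value is 1000 nM with an expected range from 150 nM to 7000 nM when it is measured.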

Compound 4, half-maximal inhibitory concentration: 15 nM
Compound 4: middle estimate off by 67-fold (1.82 log units), on the high side; the whole stated range lies above it.
By their numbers in this assay, from the lowest: compound 4; then compound 2; then compound 3.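

In this assay, amino in place of ethoxy on a carbonyl carbon gives a 600-fold lower number from compound 3 to compound 4 (2.78 log units; beyond the scatter), so the number at this position moves far even when the carbonyl stays and only the group on it is exchanged, whereas the earlier step replaced the whole group on the aromatic carbon. Carbamoyl in place of (diethylamino)methyl then gives a 5.2-fold lower number from compound 2 to compound 4 (0.72 log units; beyond the scatter), which shows that among these compounds the lowest number does not need the (diethylamino)methyl group of compound 2. Among these compounds, nothing available here explains why this exchange on the carbonyl carbon moves the number so far.

The compounds shown leave open whether an N-methyl amide, an N,N-dimethyl amide or a carboxylic acid on the same carbonyl carbon would give a number near that of compound 4 or near that of compound 3, and so whether the result belongs to the unsubstituted carbamoyl group alone. Among the compounds shown here, compound 1 carries no number, so no step to it can be read, and a chain ending in an ester and joined through an ether oxygen remains unplaced against the other compounds.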